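A few compounds are considered here, and "the series" means these few. Any claim that something is new, unique, unknown or untested is made for them only; others in the source may bear on it.

Measured compounds:
- compound 1, `CC(C)CNC(=O)n1c(=O)oc2ccc(C3CCN(C)CC3)cc21`: 295 nM
- compound 2, `CC(C)N1CCC(c2ccc3c(c2)oc(=O)n3C(=O)NCCCCc2ccccc2)CC1`: 94 nM

Of the compounds shown here, two have been measured in an assay on HEK293 cells for inhibition of acid ceramidase (Homo sapiens), read by fluorescence, with stated times of 10 min and 3 h; on this read-out higher numbers stand for weaker inhibition and lower numbers for stronger inhibition. Compound 1, `CC(C)CNC(=O)n1c(=O)oc2ccc(C3CCN(C)CC3)cc21`, gives 295 nM in this assay. Compound 2, `CC(C)N1CCC(c2ccc3c(c2)oc(=O)n3C(=O)NCCCCc2ccccc2)CC1`, gives 94 nM in this assay. Compound 2 stands at the lower of the two numbers, and its distance to compound 1 lies beyond the usual scatter of the measurement. Among the measured compounds shown here, both compounds share a core, and they differ in more than one place, so no single step between them can be read from the pair.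

Compound 3, `CN1CCN(c2ccc3c(c2)oc(=O)n3C(=O)NCCCCc2ccccc2)CC1`, has not yet been measured. It differs from compound 2 in one place: 4-methylpiperazin-1-yl in place of 1-isopropylpiperidin-4-yl on an aromatic carbon. The urea chain with the phenyl end is kept from compound 2. Nothing in the measured pair isolates the effect of such an exchange, so any expectation for compound 3 rests on the value of compound 2 alone. The step from compound 2 to compound 3 is expected to be small, probably a modest weakening, a 1.7-fold higher number from compound 2 to compound 3 (0.23 log units; within the scatter). For compound 3 in this assay the estimated value is 160 nM, with a range from 50 nM to 500 nM.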

Compound 3, half-maximal inhibitory concentration: 116 nM
Compound 3: middle estimate off by 1.4-fold (0.14 log units), on the high side, and the stated range covers the measured number.
By their numbers in this assay, from the lowest: compounds 2 and 3 (each within the scatter of the next); then compound 1.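

In this assay, among the compounds shown here, the exchange of 1-isopropylpiperidin-4-yl for 4-methylpiperazin-1-yl on the aromatic carbon gives a 1.2-fold higher number from compound 2 to compound 3 (0.09 log units; within the scatter), the first step that can be read at a single place. Compounds 1 and 2 differ in more than one place and could say nothing about this position alone, whereas this pair shows that, with the urea chain ending in phenyl kept, these two six-membered non-aromatic rings cannot be told apart by this read-out, even though the ring entering carries a second nitrogen and the alkyl group on the ring nitrogen is different. No measurement at hand bears on why the two rings give such similar numbers.

The compounds shown leave open whether this position would stay as undemanding with a morpholine ring, a piperidine with a free ring nitrogen, or a carboxylic acid in place of these rings. They also leave open how much of the higher number of compound 1 belongs to its shorter, branched urea chain and how much to its 1-methylpiperidin-4-yl ring.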